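Chloro to fluoro on the aromatic ring of compound 2

The compounds below may be only part of what the source reports. "The series", "measured", "known", "first", "only" and "open" are said of these compounds alone.

In a functional assay on A549 cells (Homo sapiens) for inhibition, read by MTT assay, with a stated time of 72 h (on this read-out higher numbers stand for weaker inhibition and lower numbers for stronger inhibition), compound 2 `CC(C)(C)n1cc2c(n1)C(=O)CC1(CCN(C(=O)c3cc(-c4ccc(Cl)cc4)nc4ccccc34)CC1)O2` gives 2330 nM and compound 1 `Cc1ccccc1-c1cc(C(=O)N2CCC3(CC2)CC(=O)c2nn(C(C)(C)C)cc2O3)c2ccccc2n1` gives 1880 nM so the two stand within the scatter of each other. Compound 3 `CC(C)(C)n1cc2c(n1)C(=O)CC1(CCN(C(=O)c3cc(-c4ccc(F)cc4)nc4ccccc34)CC1)O2` keeps the shared core of compound 2 and carries fluoro in place of chloro on an aromatic carbon, para to a large group fluoro in place of chloro on an aromatic carbon which reads as 4-chlorophenyl to 4-fluorophenyl. Among the measured compounds shown here, only one measured step bears on this change: a 1.2-fold higher number from compound 1 to compound 2 (0.09 log units; within the scatter) with 4-chlorophenyl in place of 2-methylphenyl, and it stays within the scatter. For the measured compounds named here, no measured step exchanges one halogen for another, so this evidence is indirect. The expected step of a 1.1-fold lower number from compound 2 to compound 3 (0.02 log units; within the scatter) is none beyond the scatter in this assay with no direction favoured. For compound 3 the estimated value is 2200 nM with an expected range of 1100 nM to 4400 nM on this read-out.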

Compound 3, half-maximal inhibitory concentration: 5770 nM
The estimate for compound 3 lay 2.6-fold (0.42 log units) below the measured number, outside the stated range (above it).
By their numbers in this assay, from the lowest: compounds 1 and 2 (each within the scatter of the next); then compound 3.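

In this assay, this position on the aromatic ring, para to a large group, turns out to respond to its substituent: fluoro in place of chloro gives a 2.5-fold higher number from compound 2 to compound 3 (0.39 log units; beyond the scatter). The earlier pair, 4-chlorophenyl and 2-methylphenyl, stood within the scatter of each other and gave no sign of this, while 4-fluorophenyl in place of 2-methylphenyl gives a 3.1-fold higher number from compound 1 to compound 3 (0.49 log units; beyond the scatter), so 4-fluorophenyl separates from both of the other aryl groups. Nothing at hand explains why the halogen exchange moves the number.

The compounds shown leave open whether this sensitivity is confined to the halogens or extends to other groups at the same place, such as bromo, methoxy or an amine. They also leave open whether the chloro to fluoro step keeps its size on a different core, as the shared core does not vary here.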